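Two Amides Measured, an Indolylmethyl Analogue Awaited

This account rests on a few compounds, and the source may have more. Where it says the series, first, only, none or still open, it means among the compounds named here.

Measured so far:
- compound 1 `CNC(=O)c1cc(C(=O)NC2CCOCC2)cn(Cc2ccccc2)c1=O`: 2.8
- compound 2 `CNC(=O)c1cc(C(=O)NC2CC2)cn(Cc2cccc(OC)c2)c1=O`: 3

In a physicochemical assay for lipophilicity, at pH 7.4 (on this read-out higher numbers stand for higher lipophilicity and lower numbers for lower lipophilicity), compound 1 gives 2.8. In this assay compound 2 gives 3. Compound 2 holds the higher of the two numbers, with compound 1 nearest, its value lower by an amount within the usual scatter, so the two cannot be told apart on this read-out. For the measured compounds named here, no step between compounds differing in one place is available here.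

Compound 3 `CNC(=O)c1cc(C(=O)NC2CC2)cn(Cc2cccc3cc[nH]c23)c1=O` has not been measured. It differs from compound 2 in one place: 1H-indol-7-yl in place of 3-methoxyphenyl on a saturated chain carbon bound to an aromatic nitrogen. Going by the values given here, since no directly comparable step is known, the expected step from compound 2 to compound 3 in this assay is small, a number 0.10 log units higher from compound 2 to compound 3 (within the scatter), likely within the scatter rather than a clear shift in either direction. Compound 3 is accordingly expected to give about 3.1, with a range from 2.6 to 3.6.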

Compound 3, distribution coefficient: 3.7
Estimate against measurement, compound 3: 0.60 log units below; the measured number lies above the stated range.
By their numbers in this assay, from the lowest: compounds 1 and 2 (each within the scatter of the next); then compound 3.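

In this assay, this position proves able to register a clear change: 1H-indol-7-yl in place of 3-methoxyphenyl on a saturated chain carbon bound to an aromatic nitrogen gives a number 0.70 log units higher from compound 2 to compound 3 (beyond the scatter). The exchange alters several things at once, since 3-methoxyphenyl has 8 heavy atoms, 0 hydrogen-bond donors and 1 hydrogen-bond acceptor, while 1H-indol-7-yl has 9 heavy atoms, 1 hydrogen-bond donor and 0 hydrogen-bond acceptors. No measurement presented here ties the step to any one of these differences.

The compounds shown leave open whether a naphthalen-1-yl group, with two fused aromatic rings and no ring nitrogen, would give a similar number. They also leave open whether the same exchange would give a step of this size with the other amide of compound 1.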